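The compounds below may be only part of what the source reports. "The series", "measured", "known", "first", "only" and "open" are said of these compounds alone.

Measured compounds in the series:
compound 1 `Cc1nc(SCC(=O)Nc2nc(-c3ccc(Cl)cc3)cs2)n(Nc2ccccc2)c1C` — 4170 nM
compound 2 `Cc1ccc(Nn2c(SCC(=O)Nc3nc(-c4ccccc4)cs3)nc(C)c2C)cc1` — 10200 nM

Both were tested in a functional assay on NCI-H322M cells (Homo sapiens) for antiproliferative activity, read by sulforhodamine B assay, with a stated time of 48 h; on this read-out higher numbers stand for weaker inhibition of growth and lower numbers for stronger inhibition of growth. Compound 1 holds the lower of the two numbers; compound 2 stands higher, and that gap lies beyond the usual scatter. Among the compounds with values here, compound 2 differs from compound 1 in more than one place, so its value shows only that this combination of changes goes with a weaker result; no single-change step between measured compounds is available.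

Compound 3 `COc1ccc(Nn2c(SCC(=O)Nc3nc(-c4ccc(Cl)cc4)cs3)nc(C)c2C)cc1` derives from compound 1 by methoxy in place of hydrogen on an aromatic carbon. Within the data shown here, with no measured step to lean on, the expectation is a small move toward a higher number, near the edge of the scatter, rather than a marked change in either direction. The expected step of a 1.4-fold higher number from compound 1 to compound 3 (0.14 log units; within the scatter) is thus modest. Compound 3 is estimated at 5800 nM, with a range from 2200 nM to 16000 nM.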

Compound 3, concentration for 50% growth inhibition: > 100000 nM
Compound 3: no number, only a limit; the forecaster's own chance of this, stated with the estimate: 10%; middle value at least 17-fold (1.23 log units) away from the limit.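

In this assay compound 3 gives > 100000 nM, which is a limit of the assay and not a number: the limit of > 100000 nM in this assay, at which 1 of the 3 values shown sits.

Within the data shown here, the first single-place change, methoxy in place of hydrogen on an aromatic carbon para to a large group, gives an at least 23-fold higher number from compound 1 to compound 3 (1.37 log units; beyond the scatter). This position is therefore sensitive to substitution in a way the earlier comparison could not show, as compound 2 differs from compound 1 in more than one place.

On these data alone, whether this loss is specific to methoxy or extends to other groups at this position stays open; a fluorine, a hydroxyl or an amine there would help separate the two readings. The true size of the step also stays unknown, and these compounds give no cause for it.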